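The source may hold more compounds than are shown below. What is called first, only, known or untested is meant among the compounds shown, and "the series" means these compounds.

Working notes on the carbonyl-substituent series

All three measured compounds share one core and differ only in the group attached at the carbonyl. Compound 1 `Cc1nc(S(C)(=O)=O)ccc1Oc1ncnc(OC2CCN(C(=O)OC(C)(C)CF)CC2)c1F` gives 138 nM in a functional assay on isolated protein for inhibition of Glucose-dependent insulinotropic receptor (Rattus norvegicus), read by HTRF and cAMP accumulation; on this read-out lower numbers stand for an effect already at smaller amounts and higher numbers for an effect only at larger amounts of compound. Compound 2 `Cc1nc(S(C)(=O)=O)ccc1Oc1ncnc(OC2CCN(C(=O)OC(C)F)CC2)c1F` gives 315 nM in this assay, the step being a 2.3-fold higher number from compound 1 to compound 2 (0.36 log units; beyond the scatter). Compound 3 `Cc1nc(S(C)(=O)=O)ccc1Oc1ncnc(OC2CCN(C(=O)SC3CCC3)CC2)c1F` gives 77.4 nM in this assay; it carries the lowest of the three numbers, with a 1.8-fold lower number from compound 1 to compound 3 (0.25 log units; within the scatter) and a 4.1-fold lower number from compound 2 to compound 3 (0.61 log units; beyond the scatter), so only its gap to compound 2 lies beyond the scatter.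

Compound 4 `Cc1nc(S(C)(=O)=O)ccc1Oc1ncnc(OC2CCN(C(=O)c3nc(C(C)(C)F)no3)CC2)c1F` is not yet measured in this assay. Relative to compound 3 the change is a group of 9 heavy atoms (5 carbon, 2 nitrogen, 1 oxygen, 1 fluorine; one five-membered aromatic ring with 3 hetero atoms) in place of a group of 5 heavy atoms (4 carbon, 1 sulfur; one four-membered non-aromatic ring of carbon only), on a carbonyl carbon. Within the data shown here, the steps that bear on it are the three among compounds 1, 2 and 3, all exchanges of the group attached at the carbonyl; they ranged from within the scatter to modest, and none introduced an aromatic ring of the kind entering here, so the direction is open. A step of a 1.4-fold higher number from compound 3 to compound 4 (0.15 log units; within the scatter) is expected, that is, nothing clearly beyond the scatter. For compound 4 a value of 110 nM is expected, with a range from 35 nM to 350 nM.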

Compound 4, half-maximal effective concentration: 606 nM
Estimate against measurement, compound 4: 5.5-fold (0.74 log units) below; measured number above the stated range.
By their numbers in this assay, from the lowest: compounds 3 and 1 (each within the scatter of the next); then compounds 2 and 4 (each within the scatter of the next).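

Notes on compound 4: in this assay, the first group with an aromatic ring on this carbonyl carbon gives the largest step seen so far in the series, a 7.8-fold higher number from compound 3 to compound 4 (0.89 log units; beyond the scatter), against cyclobutylsulfanyl. The comparison with the two groups without a ring is split: a 4.4-fold higher number from compound 1 to compound 4 (0.64 log units; beyond the scatter), whereas a 1.9-fold higher number from compound 2 to compound 4 (0.28 log units; within the scatter), leaving compound 4 not separated from compound 2. Nothing measured on these compounds accounts for these steps.

The compounds shown leave open whether the step goes with the five-membered aromatic ring with 3 hetero atoms in particular or with any aromatic ring at this place. A phenyl group or a dimethylamino group on the same carbonyl carbon would bear on that question.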